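A few compounds are considered here, and "the series" means these few. Any claim that something is new, unique, unknown or untested is made for them only; others in the source may bear on it.

Of the compounds shown here, three from one series have been tested in a functional assay on HepG2 cells (Homo sapiens) for inhibition, read by MTT assay, with a stated time of 48 h, tested at 10 uM; a lower number here means less inhibition of growth, a higher number more inhibition of growth at the concentration tested. Compound 1, `O=C(/C=C/c1ccc(OCc2cn(Cc3cccc(F)c3)nn2)cc1)c1ccc(Br)cc1`, gives 34% in this assay. Compound 2, `O=C(/C=C/c1ccc(OCc2cn(Cc3ccc(F)cc3)nn2)cc1)c1ccc(Br)cc1`, gives 22% in this assay, and compound 3, `COc1ccc(C(=O)/C=C/c2ccc(OCc3cn(Cc4cccc(F)c4)nn3)cc2)cc1`, gives 22% in this assay.

Two single changes connect these values. The change 4-fluorophenyl in place of 3-fluorophenyl on a saturated chain carbon bound to an aromatic nitrogen produces a number 12 percentage points lower from compound 1 to compound 2 (beyond the scatter). The change methoxy in place of bromo on an aromatic carbon produces a number 12 percentage points lower from compound 1 to compound 3 (beyond the scatter). Compound 2 and compound 3 thus stand level with each other at the digits recorded, and together they hold the lower of the numbers seen so far, with compound 1 standing higher than both.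

Compound 4, `COc1ccc(C(=O)/C=C/c2ccc(OCc3cn(Cc4ccc(F)cc4)nn3)cc2)cc1`, has not yet been measured. It differs from compound 3 by 4-fluorophenyl in place of 3-fluorophenyl on a saturated chain carbon bound to an aromatic nitrogen. This is the same change as the one from compound 1 to compound 2, made at the same place, and it occurs twice among these four compounds. The cores on which the two changes are made differ by methoxy in place of bromo on an aromatic carbon.

Within the data shown here, because the first instance of this change gave a number 12 percentage points lower from compound 1 to compound 2 (beyond the scatter), the step from compound 3 to compound 4 is expected to be of a similar size, namely a number 10 percentage points lower from compound 3 to compound 4 (within the scatter), although it rests on a single earlier example and the core carries a different group in the two cases. On that basis compound 4 is estimated to give 12% in this assay, with a plausible range from 2% to 26%.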

Compound 4, percent growth inhibition at one concentration: 21%
Estimate against measurement, compound 4: 9 percentage points below; the range from low to high includes it.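

On the core of compound 3, 4-fluorophenyl in place of 3-fluorophenyl gives a number 1 percentage points lower from compound 3 to compound 4 (within the scatter) in this assay, and with 4-fluorophenyl in place, methoxy in place of bromo gives a number 1 percentage points lower from compound 2 to compound 4 (within the scatter). Set beside the first instance, the fluorine shift does not separate the two cores, though this comparison also does not prove that the step has one common size on both: the same change on two cores in this assay, a number 12 percentage points lower (beyond the scatter) from compound 1 to compound 2 and a number 1 percentage points lower (within the scatter) from compound 3 to compound 4, 11 percentage points apart, within the scatter of two such steps The same limit applies to methoxy in place of bromo, where a single pair on each side shows neither a firm dependence on the other substituent nor a firm transfer from one core to the other: the same change on two cores in this assay, a number 12 percentage points lower (beyond the scatter) from compound 1 to compound 3 and a number 1 percentage points lower (within the scatter) from compound 2 to compound 4, 11 percentage points apart, within the scatter of two such steps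

Among these compounds, the four compounds cover only two groups at each of the two places, so it remains open how the values would run with an unsubstituted phenyl, or with chloro or trifluoromethyl in place of the fluorine on the benzyl group. Also open, as far as these compounds go, is what a dimethylamino group or a carboxylic acid in place of the bromo or methoxy would give, and whether any of these readings at one concentration would hold across a range of concentrations.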